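Cyclohexyl in Place of Propyl: What to Expect for Compound 4

The compounds below may be only part of what the source reports. "The series", "measured", "known", "first", "only" and "open" are said of these compounds alone.

Compound 1, `COc1cc(N)c(Cl)cc1NC(=O)C1CCN(Cc2ccc(Cl)cc2)CC1`, gives 1.2 mg/kg in a functional assay on the whole organism for antagonist activity, with Mus musculus as the target; a lower number here means that less compound is needed, a higher number that more compound is needed for the effect.
Compound 2, `CCCCN1CCC(C(=O)Nc2cc(Cl)c(N)cc2OC)CC1`, reaches only a limit of this assay, > 10 mg/kg.
Compound 3, `COc1cc(N)c(Cl)cc1NC(=O)C1CCN(Cc2ccc(C)c(C)c2)CC1`, also reaches only a limit of this assay, > 8 mg/kg.

Compound 2 thus stands at a limit, not at a number, and one further value shown is likewise a limit. The piece follows the change from compound 2 to compound 4, `COc1cc(N)c(Cl)cc1NC(=O)C1CCN(CC2CCCCC2)CC1`, which is cyclohexyl in place of propyl on a saturated chain carbon bound to an amine nitrogen in a ring.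

Among the measured compounds shown here, no measured step makes this same change. The two steps that touch the same place both start from compound 1: an at least 8.3-fold higher number from compound 1 to compound 2 (0.92 log units; beyond the scatter) and an at least 6.6-fold higher number from compound 1 to compound 3 (0.82 log units; beyond the scatter). Both go to a limit, so they show that leaving 4-chlorophenyl costs at least a modest amount, but they do not say whether a non-aromatic six-membered ring recovers any of it. The step from compound 2 to compound 3 is unreadable because both end at a limit.

The expectation for compound 4 is therefore uncertain: a value somewhat lower than the limit of compound 2 is estimated, an at least 2.0-fold lower number from compound 2 to compound 4 (0.30 log units; that floor lies within the scatter), with a real chance that only a limit is reported again. Compound 4 is estimated at 5 mg/kg, between 1.5 mg/kg and 15 mg/kg.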

Compound 4, dose for half-maximal effect: 2.9 mg/kg
Beside the measured number, compound 4's estimate is 1.7-fold (0.24 log units) above it; low and high end bracket the measured number.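

In this assay, among the compounds shown here, compound 4 is the only compound besides compound 1 that gives a number rather than a limit, so a six-membered non-aromatic ring of carbon only can work at this place, on a saturated chain carbon bound to an amine nitrogen in a ring. Compound 2 and compound 3 each stand at a limit of the assay, so the next two steps are floors rather than full sizes, an at least 3.4-fold lower number from compound 2 to compound 4 (0.53 log units; beyond the scatter) and an at least 2.7-fold lower number from compound 3 to compound 4 (0.44 log units; beyond the scatter), while the step between compound 2 and compound 3 cannot be read. An aromatic ring is therefore not needed here, and compound 3 shows that having one is not enough, yet 4-chlorophenyl keeps a modest lead, with a 2.4-fold higher number from compound 1 to compound 4 (0.38 log units; beyond the scatter).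

The compounds shown leave open whether the ring itself matters or simply the larger group, which a straight hexyl chain at this place could help to separate. They also leave open how much of the lead of compound 1 rests on its chlorine, which unsubstituted phenyl or 4-fluorophenyl could test.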